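This account rests on a few compounds, and the source may have more. Where it says the series, first, only, none or still open, it means among the compounds named here.

Measured in a functional assay on SW-620 cells (Homo sapiens) for cytotoxicity, read by MTT assay, with stated times of 4 h and 72 h, tested at 5 uM; on this read-out lower numbers stand for stronger inhibition and higher numbers for weaker inhibition:
- Compound 1 `Cc1cc(Nc2ccc(C(=O)/C=C/c3ccc4ccccc4c3)cc2)n2nc(SCc3ccc(F)cc3)nc2n1`: 320 nM
- Compound 2 `Cc1cc(Nc2ccc(C(=O)/C=C/c3ccc4ccccc4c3)cc2)n2nc(SCc3ccccc3[N+](=O)[O-])nc2n1`: 960 nM
- Compound 3 `Cc1cc(Nc2ccc(C(=O)/C=C/c3ccc4ccccc4c3)cc2)n2nc(SCc3ccccc3Br)nc2n1`: 420 nM

Among these, compound 3 gives 420 nM, within the scatter of compound 1 and clearly under compound 2. Compound 4 `Cc1cc(Nc2ccc(C(=O)/C=C/c3ccc4ccccc4c3)cc2)n2nc(SCc3ccc(Br)cc3)nc2n1` has not yet been measured. It carries 4-bromophenyl in place of 2-bromophenyl on a saturated chain carbon bound to a sulfur. Going by the values given here, no measured step moves the bromine on its own, so the evidence is indirect. The nearest comparison is a 1.3-fold higher number from compound 1 to compound 3 (0.12 log units; within the scatter), with 2-bromophenyl in place of 4-fluorophenyl. The two modest steps both involve the nitro group of compound 2: a 3.0-fold higher number from compound 1 to compound 2 (0.48 log units; beyond the scatter) and a 2.3-fold lower number from compound 2 to compound 3 (0.36 log units; beyond the scatter). Compound 4 has no nitro group, so on the strength of a 1.3-fold higher number from compound 1 to compound 3 (0.12 log units; within the scatter) no step beyond the scatter is expected in this assay. The estimated change is a 1.2-fold lower number from compound 3 to compound 4 (0.07 log units; within the scatter). Compound 4 is expected at 360 nM, with an estimated range from 170 nM to 760 nM.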

Compound 4, half-maximal inhibitory concentration: 370 nM
For compound 4 the middle estimate is 1.0-fold (0.01 log units) below the measured one; the measured number falls inside the stated range.
By their numbers in this assay, from the lowest: compounds 1, 4 and 3 (each within the scatter of the next); then compound 2.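

In this assay, going by these compounds alone, moving the bromine alone, from 2-bromophenyl to 4-bromophenyl, gives a 1.1-fold lower number from compound 3 to compound 4 (0.06 log units; within the scatter) and so stays within the usual scatter, which is the first direct test of where this halogen sits on the ring. Bromo in place of fluoro on an aromatic carbon gives a 1.2-fold higher number from compound 1 to compound 4 (0.06 log units; within the scatter) and also stays within the scatter, whereas 4-bromophenyl in place of 2-nitrophenyl gives a 2.6-fold lower number from compound 2 to compound 4 (0.41 log units; beyond the scatter) and goes beyond it. Among these four compounds, compound 2 alone stands apart, while compounds 1, 3 and 4 cannot be told apart from their nearest neighbours in the order.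

Nothing shown explains why compound 2 differs from the others. Also open, from the compounds shown here alone, is whether a 4-nitrophenyl group, an amine on the ring or a longer chain on the sulfur would shift the number.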